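Adding a pyrrolidinylcarbonyl group to a pyrimidine aniline

This account rests on a few compounds, and the source may have more. Where it says the series, first, only, none or still open, it means among the compounds named here.

Measured so far:
Compound 1, `COc1cc(Nc2nc(C)cc(N3CCCC3)n2)ccc1F`, 220000 nM
Compound 2, `COc1cc(Nc2nccc(N(C)C)n2)ccc1F`, 160000 nM

In a physicochemical assay for solubility, read by nephelometry, measured as kinetic solubility (on this read-out higher numbers stand for higher solubility and lower numbers for lower solubility), compound 1 gives 220000 nM. In this assay compound 2 gives 160000 nM, the lowest of the two numbers, but its gap to compound 1 is within the scatter, so the two compounds cannot be told apart on this read-out. Among the measured compounds shown here, no step between measured compounds is recorded, so there is no earlier example of a comparable change to lean on.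

Compound 3, `COc1cc(Nc2nc(C(=O)N3CCCC3)cc(N(C)C)n2)ccc1F`, has not yet been measured. It differs from compound 2 in one place: (pyrrolidin-1-yl)carbonyl in place of hydrogen on an aromatic carbon. Both compounds keep the same shared core and the same dimethylamino group.

For the measured compounds named here, with no recorded step to guide the expectation, a modest decrease is expected, a 1.6-fold lower number from compound 2 to compound 3 (0.20 log units; within the scatter), which may still fall within the scatter. On that basis compound 3 is expected to give about 100000 nM in this assay, with a plausible range from 30000 nM to 250000 nM.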

Compound 3, solubility: > 250000 nM
Compound 3: no number, only a limit; the forecaster's own chance of this, stated with the estimate: 15%; middle value at least 2.5-fold (0.39 log units) from the limit.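

In this assay compound 3 gives > 250000 nM, which is a limit of the assay and not a number. Read against compound 2, the change is an at least 1.5-fold higher number from compound 2 to compound 3 (0.19 log units; that floor lies within the scatter), so the earlier compounds' high read-out survives when this aromatic carbon, next to the ring nitrogen, carries a (pyrrolidin-1-yl)carbonyl group in place of hydrogen, and a group of 7 heavy atoms brings no visible loss at this position. The step has a floor but no upper end, so it can show only that no drop was seen, not how large any rise is, and the single relevant record is this: the limit of > 250000 nM in this assay, at which 1 of the 3 values shown sits.

From the compounds shown here alone, what remains open is which part of the new group matters, the carbonyl or the pyrrolidine ring, and a morpholine amide or a carboxylic acid on the same carbon would help to separate the two. Going by these compounds, whether any such group would give a number rather than another limit in this assay also stays open, so a ranking of groups at this position cannot yet be drawn.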